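A few compounds are considered here, and "the series" means these few. Any claim that something is new, unique, unknown or untested is made for them only; others in the source may bear on it.

Of the compounds shown here, two built on a shared core have so far been tested in an assay on isolated protein for inhibition of Amine oxidase [flavin-containing] A (Homo sapiens), read by fluorescence and Amplex Red, with a stated time of 15 min, tested at 50 uM; on this read-out lower numbers stand for less inhibition and higher numbers for more inhibition at the one concentration tested (going by the name of the read-out). Compound 1 `C#CCN(Cc1cn(-c2cc(NC(=S)NCC)ncn2)cn1)C(C)=O` gives 4.83% in this assay, and compound 2 `C#CCN(CC#N)Cc1cn(-c2cc(NC(=S)NCC)ncn2)cn1` gives 2.01%. For the measured compounds named here, the one measured step, cyanomethyl in place of acetyl on an amine nitrogen, amounts to a number 2.8 percentage points lower from compound 1 to compound 2 (within the scatter), so both numbers sit near the bottom of the scale and cannot be told apart. Compound 2 stands lowest of the two numbers, with compound 1 nearest, and that gap lies within the scatter.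

Compound 3 `C#CCN(CC#C)Cc1cn(-c2cc(NC(=S)NCC)ncn2)cn1` has not yet been measured. It differs from compound 2 in one place: ethynyl in place of cyano on a saturated chain carbon bound to an amine nitrogen. Going by the values given here, no measured step bears directly on this exchange. Among the compounds with values here, the only step in hand concerns a different substituent on the same nitrogen and was itself within the scatter. Within the data shown here, because compound 2 gives 2.01% and the one known change in this region left the read-out where it was, no step beyond the scatter is expected in this assay. The step from compound 2 to compound 3 is estimated at a number 3 percentage points higher from compound 2 to compound 3 (within the scatter). Compound 3 is therefore expected to give 5%, in a range from -5% to 15%.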

Compound 3, a percentage reported as inhibition, at one concentration (the size of the read-out at that concentration, not a potency): 15.5%
Estimate against measurement, compound 3: 10.5 percentage points below; measured number above the stated range.
By their numbers in this assay, from the lowest: compounds 2 and 1 (each within the scatter of the next); then compound 3.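

In this assay, the group on this amine nitrogen does make a difference: ethynyl in place of cyano gives a number 13.5 percentage points higher from compound 2 to compound 3 (beyond the scatter), and propargyl in place of acetyl gives a number 10.7 percentage points higher from compound 1 to compound 3 (beyond the scatter). The earlier step could not separate acetyl from cyanomethyl, whereas propargyl stands apart from both, so among these three compounds the propargyl group alone lifts the number beyond the scatter, though compound 3 still reaches only 15.5% at the one concentration tested. Nothing available here explains why this exchange raises the read-out.

As far as these compounds go, it remains open whether the rise depends on the carbon-carbon triple bond, which a plain propyl group on the same nitrogen would test, or whether a longer chain such as butynyl would raise the number further or lower it again. From the compounds shown here alone, a single-concentration read-out of this size also leaves open how compound 3 would behave across a range of concentrations, so its potency remains unknown.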